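This account rests on a few compounds, and the source may have more. Where it says the series, first, only, none or still open, it means among the compounds named here.

Compound 1 `c1cncc(-c2ccccc2OCC2=NCCN2)c1` in a functional assay for activation of Alpha-1A adrenergic receptor (Homo sapiens), read by calcium flux (on this read-out lower numbers stand for an effect already at smaller amounts and higher numbers for an effect only at larger amounts of compound), gives 2 nM, the only number shown in this series. Compound 2 `c1ccc(-c2ccncn2)c(OCC2=NCCN2)c1` in this assay gives only a limit, < 100000 nM. The change a step that the limit leaves unreadable from compound 1 to compound 2 is therefore of unknown size, since (the limit of < 100000 nM in this assay, at which 1 of the 2 values shown sits). Compound 3 `Cc1cnsc1-c1ccccc1OCC1=NCCN1` differs from compound 1 by 4-methyl-1,2-thiazol-5-yl in place of pyridin-3-yl on an aromatic carbon. Among the measured compounds shown here, no measured step bears directly on this change; the only comparison at this position is unreadable. Compound 3 is expected to reach 200 nM, with a range from 10 nM to 5000 nM. This estimate implies an expected step of a 100-fold higher number from compound 1 to compound 3 (2.00 log units; beyond the scatter).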

Compound 3, half-maximal effective concentration: 12.6 nM
Compound 3: the middle estimate sits 16-fold (1.20 log units) above what was measured; measured number inside the range.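

In this assay, among the compounds shown here, 4-methyl-1,2-thiazol-5-yl in place of pyridin-3-yl gives a 6.3-fold higher number from compound 1 to compound 3 (0.80 log units; beyond the scatter), the first step at this position with a readable size. It shows that a five-membered aromatic ring with 2 hetero atoms can stand here and still give a measured number, though one beyond the scatter from that of compound 1. Compound 2 gives only a limit, so neither of its steps can be read: the limit of < 100000 nM in this assay, at which 1 of the 3 values shown sits.

Open, on these data alone, is how the methyl on the 1,2-thiazol-5-yl ring contributes to this result. Also open, as far as these compounds go, is how a plain phenyl ring or an aminomethyl group would read at this place.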